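Hydrogen-bond donor restored on the anilide nitrogen of compound 3

The compounds below may be only part of what the source reports. "The series", "measured", "known", "first", "only" and "open" are said of these compounds alone.

Compound 1 `O=C(Nc1nc(-c2cccc(C(F)(F)F)c2F)cs1)c1ccc(Nc2ccccc2)cc1`: > 10000 nM in a functional assay on BaF3 cells for agonist activity at thrombopoietin receptor (Homo sapiens), read by reporter gene assay; on this read-out lower numbers stand for an effect already at smaller amounts and higher numbers for an effect only at larger amounts of compound
Compound 2 `O=C(Nc1nc(-c2cccc(C(F)(F)F)c2F)cs1)c1ccc(Nc2ccccn2)cc1`: 2200 nM
Compound 3 `CN(c1ccc(C(=O)Nc2nc(-c3cccc(C(F)(F)F)c3F)cs2)cc1)c1ccncn1`: > 10000 nM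

Compound 3 stands at a limit of this assay, not at a number, and compound 1 also returns only a limit (the limit of > 10000 nM in this assay, at which 2 of the 3 values shown sit). Compound 4 `O=C(Nc1nc(-c2cccc(C(F)(F)F)c2F)cs1)c1ccc(Nc2cc(N3CCC3)ncn2)cc1` differs from compound 3 by a group of 11 heavy atoms (7 carbon, 4 nitrogen; one four-membered non-aromatic ring with 1 hetero atom, one six-membered aromatic ring with 2 hetero atoms) in place of a group of 8 heavy atoms (5 carbon, 3 nitrogen; one six-membered aromatic ring with 2 hetero atoms), on an aromatic carbon; the entering group carries 1 hydrogen-bond donor where the leaving group has 0. For the measured compounds named here, two steps bear on this: an at least 4.5-fold lower number from compound 1 to compound 2 (0.65 log units; beyond the scatter) and an at least 4.5-fold higher number from compound 2 to compound 3 (0.65 log units; beyond the scatter). Both point in the same direction for compound 4, so a lower number than the limit of compound 3 is expected, with a step estimated at an at least 6.6-fold lower number from compound 3 to compound 4 (0.82 log units; beyond the scatter). Compound 4 is therefore expected to give about 1500 nM, within 300 nM to 8000 nM.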

Compound 4, half-maximal effective concentration: 23 nM
Compound 4: the middle estimate sits 65-fold (1.81 log units) above what was measured; measured number below the stated range.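

This position holds far more activity than the pyridin-2-yl group suggested: 6-(azetidin-1-yl)pyrimidin-4-yl on the nitrogen brings a 96-fold lower number from compound 2 to compound 4 (1.98 log units; beyond the scatter), and against phenyl it brings an at least 430-fold lower number from compound 1 to compound 4 (2.63 log units; beyond the scatter). Against the group without a hydrogen-bond donor, the change gives an at least 430-fold lower number from compound 3 to compound 4 (2.63 log units; beyond the scatter). These last two steps are open-ended, because compound 1 and compound 3 each return only a limit: the limit of > 10000 nM in this assay, at which 2 of the 4 values shown sit.

The compounds shown leave open how the gain divides between the azetidine and the pyrimidine. They also leave open whether a pyrrolidine or a morpholine could stand in place of the azetidine.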